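The source may report more compounds than this note shows. Statements on the series, on what has been measured and on what is new or still open speak of the compounds shown alone.

Three compounds share one core and differ only in the side chain of the amino-acid ester. Compound 1 `O=C(CN(c1nc(Cl)nc2[nH]cnc12)C1CC1)N[C@@H](CCC(=O)OCc1ccccc1)C(=O)OCc1ccccc1` gives 52.8% in a functional assay on the whole organism (Tail, strain ICR) with Mus musculus as the target, in the tail flick test, with a stated time of 30 min, at a dose of 25 umol/kg by the oral route; a higher number here means a stronger effect of the compound at the dose given, a lower number a weaker effect. Compound 2 `CC[C@H](C)[C@H](NC(=O)CN(c1nc(Cl)nc2[nH]cnc12)C1CC1)C(=O)OCc1ccccc1` gives 41.4% in this assay, and compound 3 `CSCC[C@H](NC(=O)CN(c1nc(Cl)nc2[nH]cnc12)C1CC1)C(=O)OCc1ccccc1` gives 22.2% in this assay. Compound 3 thus stands lowest of the three: the step of a number 30.6 percentage points lower from compound 1 to compound 3 (beyond the scatter) and the step of a number 19.2 percentage points lower from compound 2 to compound 3 (beyond the scatter) both lie beyond the scatter, as does a number 11.4 percentage points lower from compound 1 to compound 2 (beyond the scatter).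

Compound 4 `NC(=O)CC[C@H](NC(=O)CN(c1nc(Cl)nc2[nH]cnc12)C1CC1)C(=O)OCc1ccccc1` is not yet measured. It differs from compound 3 by carbamoyl in place of methylsulfanyl on a saturated chain carbon, three bonds along the chain from an amide-type nitrogen and a carbonyl carbon. Among the compounds with values here, no measured step brings a carbamoyl group into this position, so the direction of the change cannot be read from a close precedent. What the three measured steps do show is that exchanging the group at this place moves the read-out by modest to large amounts, and that the methylsulfanyl-bearing compound 3 sits at the bottom. Since compound 3 is already the lowest and compound 1, carrying a group with a carbonyl at the same place, gives 52.8%, a rise seems somewhat more likely than a further fall, though with wide uncertainty. For compound 4 in this assay the expected value is 35%, within 10% to 60%, an expected step of a number 12.8 percentage points higher from compound 3 to compound 4 (beyond the scatter).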

Compound 4, a percentage reported as activity, at one dose (the size of the read-out at that dose, not a potency): 30.8%
Compound 4: the middle estimate sits 4.2 percentage points above what was measured, and the stated range covers the measured number.
By their numbers in this assay, from the lowest: compounds 3 and 4 (each within the scatter of the next); then compound 2; then compound 1.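

In this assay, carbamoyl in place of methylsulfanyl, on a saturated chain carbon three bonds along the chain from an amide-type nitrogen and a carbonyl carbon, gives a number 8.6 percentage points higher from compound 3 to compound 4 (within the scatter), so these two quite different groups cannot be told apart at this position, even though carbamoyl brings a hydrogen-bond donor that methylsulfanyl lacks. Amino in place of benzyloxy on a carbonyl carbon gives a number 22 percentage points lower from compound 1 to compound 4 (beyond the scatter), which shows that a carbonyl at this place does not by itself go with the high number of compound 1; what is attached to that carbonyl matters as well. The 2-carbamoylethyl chain in place of sec-butyl gives a number 10.6 percentage points lower from compound 2 to compound 4 (beyond the scatter), so this chain, like 2-(methylsulfanyl)ethyl, stands below the sec-butyl compound.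

As far as these compounds go, it remains open whether a carboxylic acid at the end of this chain, or a longer chain ending in a benzyl ester or an amine, would keep the number of compound 1 or lose it. Nothing shown here explains why the numbers differ.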